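A Methylamino Swap on the Shared Core of Compound 1

This account rests on a few compounds, and the source may have more. Where it says the series, first, only, none or still open, it means among the compounds named here.

Compound 1, `COc1ncnc2c1c(-c1ccoc1)cn2[C@@H]1O[C@H](CO)[C@@H](O)[C@H]1O`, gives 28800 nM in an ADME assay on BJ cells (Homo sapiens), read by MTT assay, with a stated time of 72 h; a higher number here means a weaker inhibitor, a lower number a stronger inhibitor.
Compound 2, `COc1ncnc2c1c(-c1cccs1)cn2[C@@H]1O[C@H](CO)[C@@H](O)[C@H]1O`, gives 62800 nM in this assay.
Compound 3, `COc1ncnc2c1c(-c1ccccc1)cn2[C@@H]1O[C@H](CO)[C@@H](O)[C@H]1O`, gives only a limit in this assay, namely > 100000 nM.

Among the numbers shown, compound 1 stands lowest, with compound 2 nearest at a 2.2-fold higher number from compound 1 to compound 2 (0.34 log units; beyond the scatter). The step of an at least 3.4-fold higher number from compound 1 to compound 3 (0.54 log units; beyond the scatter) ends at the limit (the limit of > 100000 nM in this assay, at which 1 of the 3 values shown sits). The step of an at least 1.5-fold higher number from compound 2 to compound 3 (0.20 log units; that floor lies within the scatter) also ends at that limit. All three measured steps concern the group on the five-membered ring of the shared core, where furan-3-yl, thiophen-2-yl and phenyl are compared.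

Compound 4, `CNc1ncnc2c1c(-c1ccoc1)cn2[C@@H]1O[C@H](CO)[C@@H](O)[C@H]1O`, differs from compound 1 elsewhere: methylamino in place of methoxy on an aromatic carbon. Within the data shown here, no measured step touches this position, so none of them bears directly on the change, and the aryl comparisons give no guidance on its direction. Among the measured compounds shown here, with no comparable step in hand, the expectation for compound 4 in this assay is a step of a 1.1-fold lower number from compound 1 to compound 4 (0.03 log units; within the scatter), that is, none beyond the scatter. Compound 4 is therefore estimated at 27000 nM, within a range from 8000 nM to 90000 nM.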

Compound 4, half-maximal inhibitory concentration: 96300 nM
Compound 4: the middle estimate sits 3.6-fold (0.55 log units) below what was measured; measured number outside the range, above it.
By their numbers in this assay, from the lowest: compound 1; then compounds 2 and 4 (each within the scatter of the next). At a limit, above all of these: compound 3.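

Until compound 4, every measured step lay in the group on the five-membered ring, and the place next to the ring nitrogen held methoxy throughout, so that position had shown nothing in this assay. The swap now shows that this position is not silent, with a 3.3-fold higher number from compound 1 to compound 4 (0.52 log units; beyond the scatter), a move towards a weaker inhibitor on the furan-3-yl compound. The change brings in a hydrogen-bond donor that methoxy lacks, but this is one pair on one aryl group, and nothing measured here accounts for the shift.

Methylamino is shown only with furan-3-yl, and whether it moves the number the same way with thiophen-2-yl or phenyl on the five-membered ring remains open. Also open, as far as these compounds go, is how a free amine, a dimethylamino group, a hydroxyl or a longer chain such as ethoxy would read at this position, and so whether the loss follows the nitrogen itself or something specific to methylamino.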